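Swapping Hydroxyphenyl Isomers on a Shared Core

This account rests on a few compounds, and the source may have more. Where it says the series, first, only, none or still open, it means among the compounds named here.

Three measured compounds share one core and differ only in where the hydroxyl sits on each pendant ring. In a functional assay on HCT-15 cells (Homo sapiens) for cytotoxicity, read by CCK-8 assay, with a stated time of 4 days (a lower number here means a stronger inhibitor, a higher number a weaker inhibitor), compound 2 `Oc1cccc(-c2cc(-c3ccccc3O)nc(-c3ccccc3O)c2)c1` gives 5020 nM, the highest of the three numbers. Compound 1 `Oc1ccc(-c2cc(-c3cccc(O)c3)nc(-c3cccc(O)c3)c2)cc1` gives 3810 nM, a value within the scatter of compound 2. Compound 3 `Oc1ccccc1-c1cc(-c2ccccc2O)nc(-c2ccccc2O)c1` gives 2180 nM, and the step of a 2.3-fold lower number from compound 2 to compound 3 (0.36 log units; beyond the scatter) is the only one that clearly moves the number. Compound 4 `Oc1ccc(-c2cc(-c3cccc(O)c3)cc(-c3ccccc3O)n2)cc1` arises from compound 2 by 4-hydroxyphenyl in place of 2-hydroxyphenyl on an aromatic carbon. Within the data shown here, no measured step exchanges a 2-hydroxyphenyl for a 4-hydroxyphenyl directly, so the modest shift in a 2.3-fold lower number from compound 2 to compound 3 (0.36 log units; beyond the scatter) bears on it only loosely, and a change no larger than the scatter is expected in this assay. Compound 4 is therefore estimated at 3600 nM, between 1800 nM and 7000 nM, a step of a 1.4-fold lower number from compound 2 to compound 4 (0.14 log units; within the scatter) expected to stay small.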

Compound 4, half-maximal inhibitory concentration: > 50000 nM
Compound 4: no number, only a limit; the forecaster's own chance of this, stated with the estimate: 5%; middle value at least 13-fold (1.14 log units) away from the limit.
By their numbers in this assay, from the lowest: compounds 3, 1 and 2 (each within the scatter of the next, the first and the last beyond it). At a limit, above all of these: compound 4.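

With 4-hydroxyphenyl in place of 2-hydroxyphenyl next to the ring nitrogen, the change gives an at least 9.9-fold higher number from compound 2 to compound 4 (0.99 log units; beyond the scatter). Among these compounds, the two compounds have the same atoms, joined differently, so rearranging one hydroxyl at this position can shift the result far more than the modest change among the earlier compounds, a 2.3-fold lower number from compound 2 to compound 3 (0.36 log units; beyond the scatter). Compound 4 has only a limit in this assay, not a number: the limit of > 50000 nM in this assay, at which 1 of the 4 values shown sits.

From the compounds shown here alone, how far compound 4 lies past that limit stays open. So does what an amine or a carboxylic acid on the pendant ring at this position would do.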